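Swapping the Dichlorophenyl Amide for a Dimethoxyphenyl Amide

This account rests on a few compounds, and the source may have more. Where it says the series, first, only, none or still open, it means among the compounds named here.

Two measured compounds share one core and differ only in the ring attached to the carbonyl. In a functional assay on NCI60 cells (Homo sapiens) for inhibition, read by sulforhodamine B assay, with a stated time of 24 h, tested at 10 uM (a higher number here means more inhibition at the concentration tested (going by the name of the read-out), a lower number less inhibition), compound 1 `COCCCNc1nc(NC(=O)c2ccc(Cl)cc2C)cc(-c2cccnc2)n1` gives 0.78%, and compound 2 `COCCCNc1nc(NC(=O)c2ccc(Cl)cc2Cl)cc(-c2cccnc2)n1` gives 2.78%; the step of a number 2 percentage points higher from compound 1 to compound 2 (within the scatter). From the compounds shown here alone, compound 3 `COCCCNc1nc(NC(=O)c2cc(Cl)cc(Cl)c2)cc(-c2cccnc2)n1` was tested, but in this assay compound 3 gives "not determined" (no result reported), so its place on this scale is unknown. Compound 4 `COCCCNc1nc(NC(=O)c2cc(OC)cc(OC)c2)cc(-c2cccnc2)n1` differs from compound 3 by 3,5-dimethoxyphenyl in place of 3,5-dichlorophenyl on a carbonyl carbon. Among the measured compounds shown here, no measured step matches this change, and the only recorded step is within the scatter, so nothing points to a move in either direction, while both measured values sit close to no inhibition. Compound 4 is therefore expected to give 3%, with a range from -8% to 15%.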

Compound 4, a percentage reported as inhibition, at one concentration (the size of the read-out at that concentration, not a potency): 8.06%
Compound 4: middle estimate off by 5.1 percentage points, on the low side, within the range that was stated.
By their numbers in this assay, from the lowest: compounds 1, 2 and 4 (each within the scatter of the next).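

With 3,5-dimethoxyphenyl on the carbonyl carbon, this assay stays close to no inhibition, with a number 5.3 percentage points higher from compound 2 to compound 4 (within the scatter) and a number 7.3 percentage points higher from compound 1 to compound 4 (within the scatter). Compound 3 has no number, so the direct swap of 3,5-dichlorophenyl for 3,5-dimethoxyphenyl cannot be read. No evidence is available to explain these values. Still open, from the compounds shown here alone, is whether a ring carrying an amine or a carboxylic acid at this carbonyl would give a step beyond the scatter. Also open, going by these compounds, is whether a longer chain elsewhere on the shared core would do so.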